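This account rests on a few compounds, and the source may have more. Where it says the series, first, only, none or still open, it means among the compounds named here.

Compound 2 `C=CCOC(=O)Oc1ccc(/C=C/C(=O)c2c(OC)cc3c(c2O)CCC(C)(C)O3)cc1` carries allyloxy on the carbonyl carbon. In an assay on HEK293T cells for inhibition of nuclear factor NF-kappa-B complex (Homo sapiens), read by a luciferase reporter (a higher number here means a weaker inhibitor, a lower number a stronger inhibitor), compound 2 gives > 30000 nM, which is a limit of the assay and not a number. Compound 1 `COc1cc2c(c(O)c1C(=O)/C=C/c1ccc(OC(C)=O)cc1)CCC(C)(C)O2` has methyl at that carbonyl carbon. In this assay compound 1 gives > 30000 nM, again a limit. The step that the two limits leave unreadable from compound 1 to compound 2 stays unreadable because both values sit at the limit of > 30000 nM in this assay, at which 2 of the 2 values shown sit. Compound 3 `C=CC(=O)Oc1ccc(/C=C/C(=O)c2c(OC)cc3c(c2O)CCC(C)(C)O3)cc1` introduces (vinyl in place of allyloxy on a carbonyl carbon). Within the data shown here, no measured step bears on this change, and compound 2 itself stands only at a limit. Compound 3 is therefore expected to remain near that limit, estimated at 30000 nM (range 8000 nM to 100000 nM), a step of a number no higher from compound 2 to compound 3 (the limit leaves the size open).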

Compound 3, half-maximal inhibitory concentration: 8990 nM
The estimate for compound 3 lay 3.3-fold (0.52 log units) above the measured number; the range from low to high includes it.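

In this assay, vinyl on this carbonyl carbon gives a readable number where neither allyloxy nor methyl did, with an at least 3.3-fold lower number from compound 2 to compound 3 (0.52 log units; beyond the scatter) and an at least 3.3-fold lower number from compound 1 to compound 3 (0.52 log units; beyond the scatter). Both steps give only a minimum size, because compound 1 and compound 2 each stand at a limit: the limit of > 30000 nM in this assay, at which 2 of the 3 values shown sit.

The compounds shown leave open whether the double bond of vinyl matters, since ethyl on the same carbonyl carbon does not appear among them. On these data alone, how an amine at this place would read also remains open.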